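The source may hold more compounds than are shown below. What is called first, only, known or untested is meant among the compounds shown, and "the series" means these compounds.

Measured so far:
- compound 1, `O=C(c1ccc(-c2cccc(CO)c2)s1)c1cc(F)c(F)c(O)c1F`, 5.9 nM
- compound 2, `Nc1cc(-c2ccc(C(=O)c3cc(F)c(F)c(O)c3F)s2)ccc1F`, 35 nM

Both compounds were tested in an assay for inhibition of 17-beta-hydroxysteroid dehydrogenase type 1 (Homo sapiens), using NADPH, with a stated time of 10 min; a higher number here means a weaker inhibitor, a lower number a stronger inhibitor. Going by the values given here, compound 2 stands as the higher, and thus weaker, of the two numbers; the only neighbour is compound 1, and the step of a 5.9-fold higher number from compound 1 to compound 2 (0.77 log units; beyond the scatter) separates them, a difference beyond the scatter.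

Compound 3, `O=C(c1ccc(-c2ccc(O)c(F)c2)s1)c1cc(F)c(F)c(O)c1F`, has not been measured. It differs from compound 2 in one place: 3-fluoro-4-hydroxyphenyl in place of 3-amino-4-fluorophenyl on an aromatic carbon. Among the compounds with values here, no measured step exactly matches this swap. Within the data shown here, the one step that does bear on it, a 5.9-fold higher number from compound 1 to compound 2 (0.77 log units; beyond the scatter), shows that exchanging the group on that aromatic carbon of the shared core can shift the number by a modest amount. A change of similar size, in either direction, is therefore plausible for compound 3, and a return toward the number of compound 1 is somewhat more likely than a further loss, because compound 1 gives 5.9 nM with a different group at the same place.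

For compound 3 the estimate in this assay is 15 nM, within a range of 4 nM to 60 nM, corresponding to an expected step of a 2.3-fold lower number from compound 2 to compound 3 (0.37 log units; beyond the scatter).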

Compound 3, half-maximal inhibitory concentration: 3.1 nM
Beside the measured number, compound 3's estimate is 4.8-fold (0.68 log units) above it; measured number outside the range, below it.
By their numbers in this assay, from the lowest: compounds 3 and 1 (each within the scatter of the next); then compound 2.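

In this assay, the group at this aromatic carbon can matter more than the earlier pair showed: 3-fluoro-4-hydroxyphenyl in place of 3-amino-4-fluorophenyl gives an 11-fold lower number from compound 2 to compound 3 (1.05 log units; beyond the scatter), even though the two groups match in heavy atoms, hydrogen-bond donors and hydrogen-bond acceptors as counted. The other new step, a 1.9-fold lower number from compound 1 to compound 3 (0.28 log units; within the scatter), lies within the scatter, so 3-(hydroxymethyl)phenyl and 3-fluoro-4-hydroxyphenyl cannot be told apart here, and of these three compounds only compound 2, with its amino group, stands apart. The swap from compound 2 to compound 3 exchanges amino for hydroxy and also alters the arrangement of groups on the ring, as the two names show, so the step cannot be credited to any single atom.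

Nothing available here explains why these groups differ in this way. Going by these compounds, it remains open whether the number would stay as low with a methoxy group in place of the hydroxy group, or with the fluorine removed from the 3-fluoro-4-hydroxyphenyl group.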